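The source may report more compounds than this note shows. Statements on the series, on what has been measured and on what is new or still open speak of the compounds shown alone.

Compound 1 `COc1cc(-c2oc3ccccc3c(=O)c2C(=O)O)cc(OC)c1OC`: in a functional assay on Malme-3M cells (Homo sapiens) for cytotoxicity, read by MTT assay, with a stated time of 6 days (a higher number here means that more compound is needed for the effect, a lower number that less compound is needed), compound 1 gives > 25 ug/mL, a limit of the assay and not a number.
Compound 2 `COc1cc(OC)cc(-c2oc3ccccc3c(=O)c2C(=O)O)c1`: in this assay compound 2 gives > 25 ug/mL, also a limit.
Compound 3 `COc1ccc2c(=O)cc(-c3cc(OC)c(OC)c(OC)c3)oc2c1`: in this assay compound 3 gives > 25 ug/mL, again a limit.

Compound 1 and compound 2 share one core and differ in one place: methoxy in place of hydrogen on an aromatic carbon. Both values are limits, so the step that the two limits leave unreadable from compound 2 to compound 1 cannot be read. The difference between the core of compound 2 and the core of compound 3 is not broken down here. All that is known so far is that (the limit of > 25 ug/mL in this assay, at which 3 of the 3 values shown sit).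

Compound 4 `COc1cc(-c2cc(=O)c3ccc(OC)c(OC)c3o2)cc(OC)c1OC` has not yet been measured. It differs from compound 3 in one place: methoxy in place of hydrogen on an aromatic carbon. Within the data shown here, this is the same kind of change as the one from compound 2 to compound 1, but the surroundings differ: in compound 1 the new methoxy sits ortho to two methoxy groups and para to a large group, whereas in compound 4 it sits on a ring that is part of a fused system of two rings, ortho to a fused ring, ortho to one methoxy group and meta to a fused ring.

Among the measured compounds shown here, since the only comparable step, a step that the two limits leave unreadable from compound 2 to compound 1, is unreadable, there is nothing that points to a change in either direction. Compound 4 is therefore expected to behave like compound 3, with an expected step that the limit leaves unreadable from compound 3 to compound 4 in this assay. The estimate for compound 4 in this assay is 40 ug/mL, in a range from 15 ug/mL to 120 ug/mL, and most likely it will again be reported only as a limit.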

Compound 4, concentration for half-maximal effect: > 25 ug/mL
Compound 4 was reported as a limit; the forecaster's own chance of this, stated with the estimate: 80%; the middle value is on the limit's open side.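

Compound 3 and compound 4 are both reported only as a limit of the assay and not as a number, so no step can be read between them. The measurements so far share one ceiling: the limit of > 25 ug/mL in this assay, at which 4 of the 4 values shown sit.

The compounds shown leave open whether methoxy in place of hydrogen changes anything in this assay, and at what concentration any of these four compounds would reach half-maximal effect.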